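Methyl for methoxy on the shared core: clearance notes

The source may report more compounds than this note shows. Statements on the series, on what has been measured and on what is new or still open speak of the compounds shown alone.

Compound 3 `COc1ccn2c(Nc3ccc(F)cc3)c(-c3ccccn3)nc2c1` is the reference point here. In an ADME assay on microsomes from liver (Mus musculus) for metabolic stability, read by LC-MS, using NADPH, with a stated time of 60 min, tested at 1 uM, in the presence of a further agent that is not named here (on this read-out lower numbers stand for slow clearance and higher numbers for fast clearance), compound 3 gives 117 uL/min. Compound 1 `Cc1ccn2c(Nc3ccccn3)c(-c3ccccn3)nc2c1` gives 130 uL/min and compound 2 `N#Cc1ccn2c(Nc3ccc(F)cc3)c(-c3ccccn3)nc2c1` gives 146 uL/min; all three numbers lie within the usual scatter of one another, so no ordering among them is claimed. Among the measured compounds shown here, the one step in hand, a 1.2-fold lower number from compound 2 to compound 3 (0.10 log units; within the scatter), is likewise within the scatter.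

Compound 4 `Cc1ccn2c(Nc3ccc(F)cc3)c(-c3ccccn3)nc2c1` differs from compound 3 as follows: methyl in place of methoxy on an aromatic carbon. For the measured compounds named here, no measured pair reproduces this exact change; the step from compound 2 to compound 3 touches the same aromatic carbon with a different group and showed nothing beyond the scatter, and compound 1 carries the methyl with another amine partner and sits in the same band of numbers. On this basis no shift beyond the scatter is expected, and the anticipated step is a 1.1-fold higher number from compound 3 to compound 4 (0.03 log units; within the scatter). Compound 4 is therefore estimated at 125 uL/min, with a range from 70 uL/min to 220 uL/min.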

Compound 4, intrinsic clearance in a liver preparation (reported as CLH), per the amount of preparation that the assay uses: 354 uL/min
Compound 4: the middle estimate sits 2.8-fold (0.45 log units) below what was measured; the measured number lies above the stated range.
By their numbers in this assay, from the lowest: compounds 3, 1 and 2 (each within the scatter of the next); then compound 4.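

In this assay the group on this aromatic carbon, opposite the ring nitrogen, makes a difference beyond the scatter once methyl stands there: methyl in place of methoxy gives a 3.0-fold higher number from compound 3 to compound 4 (0.48 log units; beyond the scatter) and methyl in place of cyano gives a 2.4-fold higher number from compound 2 to compound 4 (0.38 log units; beyond the scatter) in the same series, both modest, whereas methoxy and cyano could not be told apart. The amine partner counts as well, since 4-fluorophenyl in place of pyridin-2-yl on the nitrogen gives a 2.7-fold higher number from compound 1 to compound 4 (0.44 log units; beyond the scatter) with the methyl kept. Methyl alone therefore does not go with a high number, and compound 1 stands against any such pattern.

From the compounds shown here alone, whether chloro, ethyl or trifluoromethyl on this carbon would follow methyl or methoxy remains open, as does the methoxy group paired with the pyridin-2-yl amine. Nothing available explains why the methyl and 4-fluorophenyl pairing stands apart.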